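The source may report more compounds than this note shows. Statements on the series, on what has been measured and on what is new or still open speak of the compounds shown alone.

Measured so far:
Compound 1, `O=C(Nc1cccc(-n2cc(-c3ccncc3)c(-c3ccc(Cl)c(O)c3)n2)c1)Nc1ccc(Cl)c(Cl)c1`: > 32500 nM
Compound 2, `COc1cc(-c2nn(-c3cccc(NC(=O)Nc4ccc(Cl)c(C(F)(F)F)c4)c3)cc2-c2ccncc2)ccc1Cl`: 4450 nM

Of the compounds shown here, two have been tested in a functional assay on HT-29 cells (Homo sapiens) for inhibition, read by sulforhodamine B assay, with a stated time of 48 h; on this read-out lower numbers stand for stronger inhibition of growth and higher numbers for weaker inhibition of growth. Compound 1 gives > 32500 nM there, which is a limit of the assay rather than a measured number. Going by the values given here, compound 2 gives 4450 nM in this assay, and this is the only true number in the set. Among the compounds with values here, compound 2 thus stands as the one compound with a measured concentration. Compound 1 and compound 2 differ in more than one place, so their two values show only that one fell beyond the limit while the other gave a number.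

Compound 3, `O=C(Nc1cccc(-n2cc(-c3ccncc3)c(-c3ccc(Cl)c(O)c3)n2)c1)Nc1ccc(Cl)c(C(F)(F)F)c1`, has not yet been measured. It differs from compound 2 by hydrogen in place of methyl on an oxygen on an aromatic ring. Compound 1 carries the same hydroxy group and sits at the limit (the limit of > 32500 nM in this assay, at which 1 of the 2 values shown sits), whereas compound 2 with its methoxy group gives a number. On that ground the change is expected to weaken growth inhibition beyond the usual scatter, with the expected step in this assay being a 3.4-fold higher number from compound 2 to compound 3 (0.53 log units; beyond the scatter). Compound 3 is therefore estimated at 15000 nM, within a range from 4000 nM to 40000 nM.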

Compound 3, concentration for total growth inhibition: 5730 nM
Compound 3: the middle estimate sits 2.6-fold (0.42 log units) above what was measured, within the range that was stated.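

In this assay, the change from methoxy to hydroxy on the aromatic ring gives a 1.3-fold higher number from compound 2 to compound 3 (0.11 log units; within the scatter), so at this position hydrogen in place of methyl on the oxygen has no effect that can be told apart from the scatter, and the hydroxy group does not by itself put a compound at the limit, as compound 1 alone might have suggested. Going by these compounds alone, with that hydroxy group kept, trifluoromethyl in place of chloro on an aromatic carbon gives an at least 5.6-fold lower number from compound 1 to compound 3 (0.75 log units; beyond the scatter), which is the first single change in this set that moves the result beyond the scatter. The one value in the set that is a limit of the assay and not a number belongs to compound 1, so the true size of this step stays unknown: the limit of > 32500 nM in this assay, at which 1 of the 3 values shown sits.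

As far as these compounds go, whether a longer chain on the oxygen, such as ethoxy, or an amine in place of the hydroxy group would give a similar number stays open. Within the data shown here, the change from methoxy to hydroxy is also seen only with trifluoromethyl present, so it remains open whether it would read the same in a compound carrying chloro there instead.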